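The source may report more compounds than this note shows. Statements on the series, on what has been measured and on what is new or still open speak of the compounds shown alone.

In a functional assay on the whole organism for inhibition, with Mus musculus as the target, with a stated time of 1 h, at a dose of 100 mg/kg by the intraperitoneal route (on this read-out lower numbers stand for less inhibition and higher numbers for more inhibition at the one dose given (going by the name of the read-out)), two compounds have been measured. Compound 1, `Cc1cccc(NC(=O)Nn2c(C)nc3ccccc3c2=O)c1`, gives 51%. Compound 2, `Cc1nc2ccccc2c(=O)n1NC(=O)Nc1ccc([N+](=O)[O-])cc1`, gives 40%, the lower of the two numbers, and its nearest neighbour is compound 1, whose number sits higher by a margin beyond the usual scatter. Among the measured compounds shown here, no step between measured compounds that differ in one place has been worked out, so the two values are all that can be compared.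

Compound 3, `Cc1nc2ccccc2c(=O)n1NC(=O)Nc1ccc(F)cc1`, has not yet been tested in this assay. It differs from compound 2 in one place: fluoro in place of nitro on an aromatic carbon. For the measured compounds named here, nothing among the measured compounds shows how this exchange moves this read-out, so the expected step from compound 2 to compound 3 is a number 2 percentage points higher from compound 2 to compound 3 (within the scatter), small and not clearly in either direction beyond the scatter. Compound 3 is therefore estimated at 42%, within a range from 22% to 62%.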

Compound 3, a percentage reported as inhibition, in the whole organism at one dose (the size of the read-out at that dose, not a potency): 45%
Estimate against measurement, compound 3: 3 percentage points below, and the stated range covers the measured number.
By their numbers in this assay, from the lowest: compounds 2, 3 and 1 (each within the scatter of the next, the first and the last beyond it).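

In this assay, fluoro in place of nitro on an aromatic carbon, para to a large group, gives a number 5 percentage points higher from compound 2 to compound 3 (within the scatter), so this read-out does not separate these two groups at this position. Compound 3 also links the series to compound 1: 4-fluorophenyl in place of 3-methylphenyl on an amide-type nitrogen gives a number 6 percentage points lower from compound 1 to compound 3 (within the scatter), so this exchange of the whole aryl group likewise stays inside the usual scatter. Nothing available explains why either step is as small as it is.

From the compounds shown here alone, whether an amine, a carboxylic acid or a longer alkyl chain on that same aromatic carbon would shift the number beyond the scatter remains open. So does the effect of replacing the methyl group on the shared core with another group, such as ethyl.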